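Working notes: 2-fluorophenyl to 4-fluorophenyl

This account rests on a few compounds, and the source may have more. Where it says the series, first, only, none or still open, it means among the compounds named here.

Measured so far in a functional assay on PANC-1 cells (Homo sapiens) for inhibition, read by MTT assay, with a stated time of 24 h; a higher number here means a weaker inhibitor, a lower number a stronger inhibitor 
- compound 1 `CC1(C)[C@H]2CC[C@]1(C)N(Cc1cn(-c3ccccc3C#N)nn1)C(=O)C2` gives 240 nM 
- compound 2 `CC1(C)[C@H]2CC[C@]1(C)N(Cc1cn(-c3ccccc3F)nn1)C(=O)C2` gives 150 nM 

Going by the values given here, compound 2 and compound 1 lie within the scatter of each other, so the numbers do not separate them, and these are the only two values available. The next compound is compound 3 `CC1(C)[C@H]2CC[C@]1(C)N(Cc1cn(-c3ccc(F)cc3)nn1)C(=O)C2` and the change from compound 2 is 4-fluorophenyl in place of 2-fluorophenyl on an aromatic nitrogen with 4-fluorophenyl in place of 2-fluorophenyl on an aromatic nitrogen. Among the compounds with values here, only one measured step bears on this (a 1.6-fold lower number from compound 1 to compound 2 (0.20 log units; within the scatter)) and it puts fluoro in place of cyano on an aromatic carbon. Within the data shown here, that step stayed within the scatter, but it is not the same kind of change, and no measured pair compares 2-fluorophenyl with 4-fluorophenyl. No step beyond the scatter is therefore expected in this assay and no direction can be assigned. The expected step is small (a 1.1-fold higher number from compound 2 to compound 3 (0.03 log units; within the scatter)) and carries wide uncertainty. The estimate for compound 3 is 160 nM with an expected range from 65 nM to 400 nM in this read-out.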

Compound 3, half-maximal inhibitory concentration: 110 nM
Estimate against measurement, compound 3: 1.5-fold (0.16 log units) above; low and high end bracket the measured number.
By their numbers in this assay, from the lowest: compounds 3, 2 and 1 (each within the scatter of the next, the first and the last beyond it).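

In this assay, 4-fluorophenyl in place of 2-fluorophenyl on the aromatic nitrogen gives a 1.4-fold lower number from compound 2 to compound 3 (0.13 log units; within the scatter), so this first direct comparison of the two fluorophenyl groups at this position does not separate them. Going by these compounds alone, the comparison with the nitrile-bearing group gives a different reading: a 2.2-fold lower number from compound 1 to compound 3 (0.34 log units; beyond the scatter) is the first step beyond the scatter, although it is modest, and it shows that the aryl group on this nitrogen can shift the number measurably even though neither compound 1 and compound 2 nor compound 2 and compound 3 are separated. Nothing available on these compounds accounts for either step.

On these data alone, the step to compound 3 exchanges both the substituent and its location on the phenyl ring, so it remains open whether the nitrile itself or its location goes with the higher number, a question that a 4-cyanophenyl group would address. Also open, as far as these compounds go, is how an unsubstituted phenyl, a 4-methoxyphenyl or a 4-aminophenyl group would read on this nitrogen, and whether any of them would stand apart from the fluorophenyl pair.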